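Replacing cyanomethyl with pyridin-4-yl on compound 3

The compounds below may be only part of what the source reports. "The series", "measured", "known", "first", "only" and "open" are said of these compounds alone.

In a physicochemical assay for solubility, measured as kinetic solubility, with a stated time of 1 h, at pH 7.4 (on this read-out higher numbers stand for higher solubility and lower numbers for lower solubility), compound 3 `N#CCC(=O)NC1=NN(c2ccc(Cl)c(Cl)c2)CC1` gives 202000 nM as the highest number in this small set. Compound 2 `O=C(Nc1nc(-c2ccc(Cl)c(Cl)c2)cs1)C1CC1` gives 3000 nM on a different core. Compound 1 `CC(=O)Nc1nc(-c2ccc(Cl)c(Cl)c2)cs1` shares that core and reports only a limit (< 1000 nM).

Compound 4 `O=C(NC1=NN(c2ccc(Cl)c(Cl)c2)CC1)c1ccncc1` has not yet been measured. It keeps the core of compound 3 but carries pyridin-4-yl in place of cyanomethyl on a carbonyl carbon.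

Among the compounds with values here, only one measured step swaps a group in that kind of place: cyclopropyl in place of methyl gave an at least 3.0-fold higher number from compound 1 to compound 2 (0.47 log units; beyond the scatter) on the other core. That step involves different groups and a different core, so it is a weak guide to this change. Compound 3 at 202000 nM has more room to fall than to rise, so a clear drop in this assay is expected, though with wide uncertainty. The expected change is a 5.1-fold lower number from compound 3 to compound 4 (0.70 log units; beyond the scatter) in this estimate. Compound 4 is expected near 40000 nM with an estimated range of 8000 nM to 150000 nM as the likely span.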

Compound 4, solubility: 9000 nM
Estimate against measurement, compound 4: 4.4-fold (0.65 log units) above; low and high end bracket the measured number.
By their numbers in this assay, from the lowest: compound 2; then compound 4; then compound 3. At a limit, below all of these: compound 1.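

In this assay pyridin-4-yl in place of cyanomethyl on a carbonyl carbon gives a 22-fold lower number from compound 3 to compound 4 (1.35 log units; beyond the scatter) and so shows that the read-out on the core of compound 3 responds strongly to the group at this place. Within the data shown here, the only earlier step of this kind gave an at least 3.0-fold higher number from compound 1 to compound 2 (0.47 log units; beyond the scatter) on another core, with different groups, and it points the other way. Both entering groups carry a ring, yet the numbers move in opposite directions, so across these compounds a ring alone does not fix the direction of change.

Going by these compounds, whether an amine or a carboxylic acid at this place would stand nearer compound 3 or compound 4 remains open, as does the size of the pyridin-4-yl step on the core of compound 1. Nothing measured here gives a cause for this drop.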